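Trimming the cinnamate to an acetyl in a dihydropyranone

The source may hold more compounds than are shown below. What is called first, only, known or untested is meant among the compounds shown, and "the series" means these compounds.

The three measured compounds share a dihydropyranone core carrying a side chain with two protected oxygens and an acylated terminal carbon. In a functional assay on HL-60 cells (Homo sapiens) for antiproliferative activity, read by MTT assay, with a stated time of 6 days (on this read-out higher numbers stand for weaker inhibition and lower numbers for stronger inhibition), compound 1 `O=C1C=C[C@@H](OCc2ccccc2)[C@@H]([C@@H](COC(=O)/C=C/c2ccccc2)OCc2ccccc2)O1` gives 610 nM. Compound 2 `COc1ccc(/C=C/C(=O)OC[C@@H](OC(C)=O)[C@H]2OC(=O)C=C[C@H]2OC(C)=O)cc1`, in which the oxygens carry acetates and the terminal ester bears a methoxylated cinnamate, gives 10000 nM in this assay. Compound 3 `COc1cccc(C(=O)OC[C@@H](OC(=O)c2cccc(OC)c2)[C@H]2OC(=O)C=C[C@H]2OC(=O)c2cccc(OC)c2)c1`, with three methoxybenzoyl esters, gives 6210 nM in this assay. Compound 1 therefore stands lowest of the three numbers, with compound 3 nearest and compound 2 furthest, both beyond the scatter.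

Compound 4 `CC(=O)OC[C@@H](OCc1ccccc1)[C@H]1OC(=O)C=C[C@H]1OCc1ccccc1` has not yet been measured. It differs from compound 1 in one place: methyl in place of 2-phenylethenyl on a carbonyl carbon. The benzyl ethers of compound 1 are kept. No pair that differs only in this place has been measured, so the size of this step is not known from the numbers shown; compounds 2 and 3 differ from compound 1 in several places at once. Within the scatter a weakening is expected for compound 4, in this assay, giving a 2.5-fold higher number from compound 1 to compound 4 (0.39 log units; beyond the scatter). Compound 4 is estimated at 1500 nM, with a range from 500 nM to 5000 nM.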

Compound 4, half-maximal inhibitory concentration: 9230 nM
Beside the measured number, compound 4's estimate is 6.2-fold (0.79 log units) below it; the whole stated range lies below it.
By their numbers in this assay, from the lowest: compound 1; then compounds 3, 4 and 2 (each within the scatter of the next).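

For the compounds shown here, with the benzyl ethers kept and only the group on the carbonyl carbon changed, trimming (2-phenylethenyl)carbonyl to acetyl gives a 15-fold higher number from compound 1 to compound 4 (1.18 log units; beyond the scatter) in this assay, the first step at this position read on its own. The size of this step shows that, with this shared core and these ethers, the antiproliferative activity of compound 1 depends strongly on what the terminal ester carries, which compounds 2 and 3 could not show since each differs from compound 1 in several places at once. Nothing measured here explains the loss.

Going by these compounds, what remains open is which part of the 2-phenylethenyl group matters, the aromatic ring or the double bond outside it, and a 3-phenylpropanoyl ester, a plain benzoyl ester or a straight hexanoyl chain would each pull these apart. On these data alone, it is also open whether the same step holds when the benzyl ethers are replaced, for example by methyl ethers, or when the ester linkage itself gives way to an amide.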